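The compounds below may be only part of what the source reports. "The series", "measured", "known", "first", "only" and "open" are said of these compounds alone.

Working notes on the series. Compound 2 `COc1cc(-c2nn(-c3cccc(NC(=O)Nc4ccc(Cl)c(Cl)c4)c3)cc2-c2ccncc2)ccc1Cl` stands at a limit only: in a functional assay on IGROV-1 cells (Homo sapiens) for inhibition, read by sulforhodamine B assay, with a stated time of 48 h (a higher number here means that more compound is tolerated, a lower number that less compound is tolerated), compound 2 reaches > 50000 nM, a limit of the assay rather than a number. Compound 1 `COc1cc(-c2nn(-c3cccc(NC(=O)Nc4cc(C(F)(F)F)cc(C(F)(F)F)c4)c3)cc2-c2ccncc2)ccc1Cl` gives 23700 nM in this assay. Compound 3 `O=C(Nc1cccc(-n2cc(-c3ccncc3)c(-c3ccc(Cl)c(O)c3)n2)c1)Nc1ccc(Cl)c(Cl)c1` sits at > 32500 nM in this assay, again a limit. The step that the two limits leave unreadable from compound 2 to compound 3 stays unreadable since both ends rest at limits (the limit of > 32500 nM in this assay, at which 1 of the 3 values shown sits, and (the limit of > 50000 nM in this assay, at which 1 of the 3 values shown sits)). Compound 4 `COc1cc(-c2nn(-c3cccc(NC(=O)c4ccccc4)c3)cc2-c2ccncc2)ccc1Cl` takes the change phenyl in place of (3,4-dichlorophenyl)amino on a carbonyl carbon from compound 2. Among the compounds with values here, no measured step touches the carbonyl side of the series, so none bears directly on this change, and with compound 2 itself at a limit no direction in this assay can be read off. Compound 4 is expected near 40000 nM (range 10000 nM to 100000 nM), an expected step of an at least 1.2-fold lower number from compound 2 to compound 4 (0.09 log units; that floor lies within the scatter) not beyond the scatter.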

Compound 4, concentration lethal to 50% of the cells: > 100000 nM
Compound 4: a limit, no number (the forecaster's own chance of this, stated with the estimate: 60%); middle value at least 2.5-fold (0.39 log units) away from the limit.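

Compound 4 stands at > 100000 nM, a limit and not a number. Within the data shown here, compound 2 also rests at a limit, so no step between compound 2 and compound 4 can be read. The compounds shown leave open the direction and size of the effect of phenyl in place of (3,4-dichlorophenyl)amino on a carbonyl carbon.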